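The source may hold more compounds than are shown below. What is called first, only, known or untested is meant among the compounds shown, and "the series" means these compounds.

Compound 1, `O=C1O[C@H]([C@@H](O)Cn2cc(-c3cc(C(F)(F)F)cc(C(F)(F)F)c3)nn2)C(OCc2ccccc2)=C1OCc1ccccc1`, measured in a functional assay on CFPAC-1 cells (Homo sapiens) for antiproliferative activity, read by MTT assay, with a stated time of 72 h (a higher number here means a weaker inhibitor, a lower number a stronger inhibitor), gives 66500 nM.
Compound 2, `O=C1O[C@H]([C@@H](O)Cn2cc(-c3cccc(O)c3)nn2)C(OCc2ccccc2)=C1OCc1ccccc1`, measured in this assay gives 54100 nM.
Compound 3, `O=C1O[C@H]([C@@H](O)Cn2ccnn2)C(OCc2ccccc2)=C1OCc1ccccc1`, not yet measured.

Both measured compounds share one core and differ only in the aryl group on the triazole. Their numbers lie within the usual scatter of one another, so the two cannot be told apart on these data, and neither can be called the stronger inhibitor. Both sit at the weak end of what this kind of cell assay can resolve.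

Compound 3 carries the change (hydrogen in place of 3-hydroxyphenyl on an aromatic carbon). The 3-hydroxyphenyl is removed and only a hydrogen remains on the triazole.

Within the data shown here, no directly comparable step has been measured, so the expectation rests only on the two numbers above. Both aryl-bearing compounds are weak, and stripping the aryl away is expected to weaken further, though perhaps by no more than the scatter. Compound 3 is therefore expected to give about 85000 nM, with a range from 35000 nM to 200000 nM. The expected step of a 1.6-fold higher number from compound 2 to compound 3 (0.20 log units; within the scatter) is a modest loss of potency.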

Compound 3, half-maximal inhibitory concentration: > 100000 nM
Compound 3: only a limit was reported (the forecaster's own chance of this, stated with the estimate: 35%); middle value at least 1.1-fold (0.07 log units) from the limit.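

With the 3-hydroxyphenyl gone from the triazole carbon, in this assay compound 3 yields only a limit, > 100000 nM, rather than a true number. Set against compound 2, this gives a step of an at least 1.8-fold higher number from compound 2 to compound 3 (0.26 log units; that floor lies within the scatter), and since that figure is only a floor, the real loss could be close to the usual scatter or well beyond it, so a drop in potency is possible but not proven. What the result does show, and the aryl-bearing compounds could not, is that a bare triazole carbon with only a hydrogen brings no measurable improvement at this position, so removing the 3-hydroxyphenyl does not rescue the weak activity of compound 2.

From the compounds shown here alone, it remains open how far compound 3 really lies from compound 2, and so whether the aryl ring contributes anything to activity at all. It is also unclear what a small group other than hydrogen on this triazole carbon would do, such as a methyl, an aminomethyl or a carboxylic acid, or whether a longer chain ending in a phenyl ring would behave more like compound 2 or compound 3.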